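A Dihydroxypropyl Carbamoyl Chain in Place of Dimethylamino

This account rests on a few compounds, and the source may have more. Where it says the series, first, only, none or still open, it means among the compounds named here.

Of the compounds shown here, three sharing one core have been measured in a functional assay on HCT-116 cells (Homo sapiens) for antiproliferative activity, read by sulforhodamine B assay, with a stated time of 72 h; a lower number here means a stronger inhibitor, a higher number a weaker inhibitor. Compound 1 `Cn1ncc(Cl)c1-c1cc(C(=O)N[C@@H]2CN[C@H](CCn3cncn3)C[C@H]2c2ccc(Cl)c(Cl)c2)oc1Cl` gives 560 nM, compound 2 `Cn1ncc(Cl)c1-c1cc(C(=O)N[C@@H]2CN[C@H](CC(N)=O)C[C@H]2c2ccc(Cl)c(Cl)c2)oc1Cl` gives 650 nM, and compound 3 `CN(C)CC[C@@H]1C[C@@H](c2ccc(Cl)c(Cl)c2)[C@H](NC(=O)c2cc(-c3c(Cl)cnn3C)c(Cl)o2)CN1` gives 1710 nM. Compound 3 therefore has the highest of the three numbers and is the weakest inhibitor of the set.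

Compound 4 `Cn1ncc(Cl)c1-c1cc(C(=O)N[C@@H]2CN[C@H](CC(=O)NCC(O)CO)C[C@H]2c2ccc(Cl)c(Cl)c2)oc1Cl`, not yet measured, differs from compound 3 as follows: (2,3-dihydroxypropyl)carbamoyl in place of (dimethylamino)methyl on a saturated chain carbon bound to a saturated ring carbon. It carries (2,3-dihydroxypropyl)carbamoyl in place of (dimethylamino)methyl on a saturated chain carbon bound to a saturated ring carbon.

The closest evidence is a 2.6-fold higher number from compound 2 to compound 3 (0.42 log units; beyond the scatter), a change at the same place that links carbamoyl with the lower number, and compound 4 also has a carbamoyl there. The step of a 3.1-fold higher number from compound 1 to compound 3 (0.48 log units; beyond the scatter) likewise leads to the higher number when the dimethylamino group enters. The step of a 1.2-fold higher number from compound 1 to compound 2 (0.06 log units; within the scatter) shows that the chains of compound 1 and compound 2 do not separate in this assay. Among the measured compounds shown here, no measured compound has a substituted carbamoyl, so the effect of the dihydroxypropyl part is unknown.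

A modest move to a lower number is expected, namely a 2.1-fold lower number from compound 3 to compound 4 (0.33 log units; beyond the scatter). For compound 4 the estimated value is 800 nM, with an expected range from 350 nM to 2000 nM.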

Compound 4, half-maximal inhibitory concentration: 7090 nM
Estimate against measurement, compound 4: 8.9-fold (0.95 log units) below; the measured number lies above the stated range.
By their numbers in this assay, from the lowest: compounds 1 and 2 (each within the scatter of the next); then compound 3; then compound 4.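

Substitution on the amide nitrogen is what matters here: in this assay, 2,3-dihydroxypropyl in place of hydrogen gives an 11-fold higher number from compound 2 to compound 4 (1.04 log units; beyond the scatter). A carbamoyl on the saturated chain carbon bound to a saturated ring carbon therefore does not by itself go with the lower number, as compound 2 had suggested, since the change from dimethylamino-bearing compound 3 gives a 4.1-fold higher number from compound 3 to compound 4 (0.62 log units; beyond the scatter). The change from the triazole-bearing chain gives a 13-fold higher number from compound 1 to compound 4 (1.10 log units; beyond the scatter), so this position, where the earlier chains differed by much smaller steps, can also accommodate a change that costs far more. Nothing available here bears on why the number rises with this chain.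

The compounds shown do not separate the effect of the two hydroxyl groups from that of substitution on the amide nitrogen as such, a question that a methyl or a 2-hydroxyethyl group on that nitrogen would address. They also leave open how a carboxylic acid on the same chain carbon would compare with the primary carbamoyl of compound 2.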